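Cinnamate esters: one methoxy removed from compound 2

The source may hold more compounds than are shown below. What is called first, only, known or untested is meant among the compounds shown, and "the series" means these compounds.

Measured so far:
compound 1 `COc1ccccc1/C=C/C(=O)OC/C=C/c1cc(OC)c(OC)cc1OC` gives 100%
compound 2 `COc1cc(OC)c(OC)cc1/C=C/COC(=O)/C=C/c1ccc(OC)c(OC)c1` gives 75%
compound 3 `COc1cc(OC)c(OC)cc1/C=C/COC(=O)/C=C/c1c(OC)ccc(OC)c1OC` gives 75%

In a functional assay on the whole organism (strain Kunming) with Mus musculus as the target, with a stated time of 0.5 h, at a dose of 300 mg/kg by the intraperitoneal route (on this read-out higher numbers stand for a weaker effect at the one dose given and lower numbers for a stronger effect), compound 2 gives 75%, level with compound 3 at the digits shown, the two together the lowest of the three numbers; the only measured step among them is a number 25 percentage points lower from compound 1 to compound 2 (beyond the scatter), which changed the aryl substitution pattern on the acid side. Compound 4 `COc1ccc(/C=C/C(=O)OC/C=C/c2cc(OC)c(OC)cc2OC)cc1` differs from compound 2 by hydrogen in place of methoxy on an aromatic carbon. That single step bears only loosely on this change, and it was modest, so for compound 4 a small move back upward, or none beyond the scatter, is expected; the expected step is a number 7 percentage points higher from compound 2 to compound 4 (within the scatter). Compound 4 is therefore estimated at 82%, within 65% to 100%.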

Compound 4, a percentage reported as activity, at one dose (the size of the read-out at that dose, not a potency): 100%
Compound 4: middle estimate off by 18 percentage points, on the low side, and the stated range covers the measured number.
By their numbers in this assay, from the lowest: compounds 2 and 3 (each within the scatter of the next); then compounds 1 and 4 (each within the scatter of the next).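

Within this assay, the 3,4-dimethoxyphenyl group holds the lower number only with both methoxy groups in place: hydrogen in place of the methoxy gives a number 25 percentage points higher from compound 2 to compound 4 (beyond the scatter) and the 4-methoxyphenyl ester loses that gain. Moving the single methoxy gives no change at the digits printed from compound 1 to compound 4 (within the scatter) and so separates 4-methoxyphenyl from 2-methoxyphenyl in no way on this read-out. No available evidence bears on the reason for this.

Open, as far as these compounds go, is whether another group on this aromatic carbon, such as hydroxy, an amine or a carboxylic acid, would hold the lower number.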